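The compounds below may be only part of what the source reports. "The series", "measured", "known", "first", "only" and "open" are said of these compounds alone.

Measured so far:
compound 1, `CCCc1ccc(/C=C/C(=O)Nc2ccc3nc(CCC)cc(N)c3c2)cc1`: 3600 nM
compound 2, `CCCc1cc(N(C)C)c2cc(NC(=O)/C=C/c3ccc(C(F)(F)F)cc3)ccc2n1`: 300 nM

In a functional assay on HEK293 cells for activation of melanin-concentrating hormone receptor 1 (Homo sapiens), read by inositol phosphate accumulation (a higher number here means that more compound is needed for the effect, a lower number that less compound is needed), compound 1 gives 3600 nM, the highest of the two numbers. Compound 2 gives 300 nM, a gap beyond the usual scatter. Within the data shown here, the two compounds differ in more than one place, so no single step between them is defined and their two values are all that can be read.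

Compound 3, `CCCc1cc(N)c2cc(NC(=O)/C=C/c3ccc(Cl)c(Cl)c3)ccc2n1`, is not yet measured. Relative to compound 1 it keeps the shared core and changes only the aryl on the double-bonded chain carbon: 3,4-dichlorophenyl in place of 4-propylphenyl on a double-bonded chain carbon bound to a double-bonded chain carbon. Among the measured compounds shown here, no measured step of this kind exists in the set. A move toward a lower number is expected, because compound 2 gives 300 nM while carrying a trifluoromethylphenyl rather than 4-propylphenyl, though the two values alone cannot separate the parts of that change. The expected step of a 4.0-fold lower number from compound 1 to compound 3 (0.60 log units; beyond the scatter) is therefore kept moderate. Compound 3 is estimated at 900 nM in this assay, with a range from 250 nM to 3000 nM.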

Compound 3, half-maximal effective concentration: 990 nM
Compound 3: middle estimate off by 1.1-fold (0.04 log units), on the low side, and the stated range covers the measured number.
By their numbers in this assay, from the lowest: compound 2; then compound 3; then compound 1.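

In this assay, among these compounds, the aryl on the double-bonded chain carbon is the first place where a single change can be read: 3,4-dichlorophenyl in place of 4-propylphenyl gives a 3.6-fold lower number from compound 1 to compound 3 (0.56 log units; beyond the scatter). With the shared core held fixed, this position alone moves the number beyond the usual scatter, and an aryl carrying two chlorine atoms serves better here than one carrying a propyl chain. No measurement at hand accounts for this step.

Open, as far as these compounds go, is whether one chlorine on the phenyl ring would do as much as two, and how an unsubstituted phenyl would compare with both groups. Compound 2 differs from compound 3 in more than one place, so its trifluoromethyl-bearing aryl cannot yet be ranked at this position.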